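The source may hold more compounds than are shown below. What is called first, only, known or untested is meant among the compounds shown, and "the series" means these compounds.

Series notes. The shared core carries a chain bound to an aromatic nitrogen; compound 1 `N#CCCn1nc(-c2ccccc2)ccc1=O` ends that chain in a nitrile, compound 2 `NC(=O)CCn1nc(-c2ccccc2)ccc1=O` in a carbamoyl group, and compound 3 `N=C(S)CCCCCn1nc(-c2ccccc2)ccc1=O` in a larger group holding nitrogen and sulfur. In a functional assay on the whole organism (stomach) for inhibition, with Rattus norvegicus as the target, at a dose of 100 mg/kg by the intraduodenal route (on this read-out lower numbers stand for less inhibition and higher numbers for more inhibition at the one dose given (going by the name of the read-out)), compound 1 gives 10.1%, compound 2 gives -2.8% and compound 3 gives 91.4%, the highest of the three numbers. The steps of a number 81.3 percentage points higher from compound 1 to compound 3 (beyond the scatter) and a number 94.2 percentage points higher from compound 2 to compound 3 (beyond the scatter) are both large, whereas a number 12.9 percentage points lower from compound 1 to compound 2 (beyond the scatter) is modest.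

Compound 4 `CC(Cn1nc(-c2ccccc2)ccc1=O)C(=N)S` keeps the nitrogen- and sulfur-bearing end but on a shorter, branched chain: a group of 5 heavy atoms (3 carbon, 1 nitrogen, 1 sulfur; no ring) in place of a group of 7 heavy atoms (5 carbon, 1 nitrogen, 1 sulfur; no ring), on a saturated chain carbon bound to an aromatic nitrogen. Among the compounds with values here, no measured step alters the chain while keeping this end group, so the two large steps into compound 3 bear only indirectly: they show that the end group, rather than the chain itself, lifts the read-out. Some fall from compound 3 is expected, of uncertain size, a number 36.4 percentage points lower from compound 3 to compound 4 (beyond the scatter). Compound 4 is estimated at 55%, within 15% to 90%.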

Compound 4, a percentage reported as inhibition, in the whole organism at one dose (the size of the read-out at that dose, not a potency): 86.4%
The estimate for compound 4 lay 31.4 percentage points below the measured number, within the range that was stated.
By their numbers in this assay, from the lowest: compound 2; then compound 1; then compounds 4 and 3 (each within the scatter of the next).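

In this assay the two chains cannot be told apart at this position, with a number 5 percentage points lower from compound 3 to compound 4 (within the scatter), so the group of 5 heavy atoms serves as well here as the group of 7 heavy atoms on a saturated chain carbon bound to an aromatic nitrogen. The nitrogen- and sulfur-bearing end also stands clear of the nitrile and carbamoyl compounds on the shorter, branched chain, with a number 89.2 percentage points higher from compound 2 to compound 4 (beyond the scatter) and a number 76.3 percentage points higher from compound 1 to compound 4 (beyond the scatter), so the high read-out is not confined to compound 3. No evidence is available to explain this result.

On these data alone, the branch and the shorter length arrive together in compound 4, so their separate contributions stay open. Also open is how a longer chain, or an amine or carboxylic acid at the chain end, would read out, and a single dose gives no potency for any of these compounds.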